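The source may hold more compounds than are shown below. What is called first, only, known or untested is meant among the compounds shown, and "the series" means these compounds.

Of the compounds shown here, two of a shared core have been tested in a functional assay on Bel-7402 cells (Homo sapiens) for cytotoxicity, read by MTT assay; a higher number here means a weaker inhibitor, a lower number a stronger inhibitor. Compound 1 `CCn1cc(-c2nc3ccc([N+](=O)[O-])cc3o2)c(=O)c2cc(F)c(N3CCNC(C)C3)c(F)c21` gives 1600 nM in this assay. Compound 2 `CCn1cc(C(=O)Nc2ccccc2N)c(=O)c2cc(F)c(N3CCNC(C)C3)c(F)c21` gives 4800 nM, the higher of the two numbers, and the gap from compound 1 lies beyond the scatter. Compound 3 `CCn1cc(C(=O)Nc2ccc(C)c([N+](=O)[O-])c2)c(=O)c2cc(F)c(N3CCNC(C)C3)c(F)c21` has not been measured; it differs from compound 2 by 4-methyl-3-nitrophenyl in place of 2-aminophenyl on an amide-type nitrogen. Going by the values given here, no measured pair shows this change, so its effect is open. A modest downward step is expected, as a 1.6-fold lower number from compound 2 to compound 3 (0.20 log units; within the scatter), since the nitro-bearing compound 1 gave the lower number. Compound 3 is therefore estimated at 3000 nM, between 900 nM and 10000 nM.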

Compound 3, half-maximal inhibitory concentration: 29100 nM
The estimate for compound 3 lay 9.7-fold (0.99 log units) below the measured number; measured number above the stated range.
By their numbers in this assay, from the lowest: compound 1; then compound 2; then compound 3.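

On the amide-type nitrogen, the aryl group clearly matters in this assay: 4-methyl-3-nitrophenyl in place of 2-aminophenyl gives a 6.1-fold higher number from compound 2 to compound 3 (0.78 log units; beyond the scatter), towards weaker inhibition. Going by these compounds alone, this is the first measured change at this place, and it shows that the group there can shift the number substantially. Nothing available accounts for the step.

The change removes the amino group and adds both methyl and nitro at once, so the compounds shown cannot assign the step to any one of them. On these data alone, how a plain phenyl or a 4-methylphenyl on this nitrogen would read remains open.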